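Swapping a nitro for a methoxy on an aryl sulfonamide

The compounds below may be only part of what the source reports. "The series", "measured", "known", "first", "only" and "open" are said of these compounds alone.

Measured compounds:
compound 1 `O=S(=O)(NCCNCc1cccc2ccccc12)c1cc(C(F)(F)F)cc(C(F)(F)F)c1`, 26000 nM
compound 2 `O=[N+]([O-])c1ccc(S(=O)(=O)NCCCCCCNCc2ccc(Br)cc2)cc1`, 9800 nM
compound 3 `O=S(=O)(NCCCNCc1ccc(Cl)c(C(F)(F)F)c1)c1cc(C(F)(F)F)cc(C(F)(F)F)c1`, 7400 nM

All three compounds share a sulfonamide joined through a chain to a secondary amine that carries a benzyl-type group, and all were tested in a functional assay on MIA PaCa-2 cells (Homo sapiens) for inhibition, read by MTT assay, with a stated time of 72 h; on this read-out higher numbers stand for weaker inhibition of growth and lower numbers for stronger inhibition of growth. Among the three numbers, compound 2 gives the second highest. Its nearest neighbour is compound 3, whose number is lower but within the usual scatter, so the two cannot be told apart with confidence. Compound 1 gives a higher number, and that gap lies beyond the scatter.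

Compound 4 `COc1ccc(S(=O)(=O)NCCCCCCNCc2ccc(Br)cc2)cc1` has not yet been measured. It differs from compound 2 in one place: methoxy in place of nitro on an aromatic carbon. For the measured compounds named here, no pair of measured compounds shows this exact change, so its effect is not known from the data here.

Without a measured example, the most cautious expectation is a step no larger than the scatter, perhaps a slight drift toward a higher number, giving an estimated step of a 1.3-fold higher number from compound 2 to compound 4 (0.12 log units; within the scatter). On that basis compound 4 is expected to give about 13000 nM in this assay, with a likely range from 4500 nM to 40000 nM.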

Compound 4, concentration for 50% growth inhibition: 13000 nM
The estimate for compound 4 equals the measured number at the digits printed, within the range that was stated.
By their numbers in this assay, from the lowest: compounds 3, 2, 4 and 1 (each within the scatter of the next, the first and the last beyond it).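

For the compounds shown here, compound 2 and compound 4 form the first pair here that differs in only one place, so this change can finally be read on its own. In this assay, going from 4-nitrophenyl to 4-methoxyphenyl gives a 1.3-fold higher number from compound 2 to compound 4 (0.12 log units; within the scatter), so the two compounds cannot be told apart, even though the group para to a large group goes from two hydrogen-bond acceptors to one and loses its double bond. For this pair, the nitro group is therefore not needed to keep growth inhibition at this level, although that level remains modest, and no measurement here explains the result.

As far as these compounds go, what stays open is whether this position accepts other groups equally well, such as an amine, a carboxylic acid or a plain hydrogen, since two groups alone cannot show how far the tolerance extends. It is also unknown whether the same swap would give a similar result with a longer chain, or on a sulfonamide whose aromatic ring carries trifluoromethyl groups, as in compound 1 and compound 3.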